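Removing the iodo and lengthening the amine link

The source may hold more compounds than are shown below. What is called first, only, known or untested is meant among the compounds shown, and "the series" means these compounds.

Of the compounds shown here, three sharing one core have been tested in a functional assay on Ca-Ski cells (Homo sapiens) for cytotoxicity, read by sulforhodamine B assay, with a stated time of 48 h; a lower number here means a stronger inhibitor, a higher number a weaker inhibitor. Compound 1 `O=c1cc(-c2ccccc2)oc2cc(OCCCCNc3nc4ccc(Cl)cc4s3)cc(O)c12` gives 12.4 ug/mL, compound 2 `O=c1cc(-c2ccccc2)oc2cc(OCCCCNc3nc4ccc(Br)cc4s3)cc(O)c12` gives 12.4 ug/mL, and compound 3 `O=c1cc(-c2ccccc2)oc2cc(OCCCCNc3nc4ccc(I)cc4s3)cc(O)c12` gives 13.2 ug/mL. Compound 3 holds the highest of the three numbers, yet its gap to compound 1 and to compound 2 stays within the scatter. The halogen exchanges moved little: no change at the digits printed from compound 1 to compound 2 (within the scatter), a 1.1-fold higher number from compound 1 to compound 3 (0.03 log units; within the scatter) and a 1.1-fold higher number from compound 2 to compound 3 (0.03 log units; within the scatter). Compound 4 `O=c1cc(-c2ccccc2)oc2cc(OCCCCNNc3nc4ccccc4s3)cc(O)c12` differs from compound 3 by (1,3-benzothiazol-2-yl)amino in place of 6-iodo-1,3-benzothiazol-2-yl on an amine nitrogen. Among the measured compounds shown here, the halogen steps bear on the loss of the iodo and all lie within the scatter, while no measured step bears on the rest of this change. Compound 4 is therefore expected to show no shift beyond the scatter in this assay, a 1.0-fold lower number from compound 3 to compound 4 (0.01 log units; within the scatter). Compound 4 is estimated at 13 ug/mL, with a range from 6.5 ug/mL to 26 ug/mL.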

Compound 4, half-maximal inhibitory concentration: 14.6 ug/mL
Compound 4: the middle estimate sits 1.1-fold (0.05 log units) below what was measured; the range from low to high includes it.
By their numbers in this assay, from the lowest: compounds 1, 2, 3 and 4 (each within the scatter of the next).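

The change from 6-iodo-1,3-benzothiazol-2-yl to (1,3-benzothiazol-2-yl)amino on the amine nitrogen gives a small step in this assay (a 1.1-fold higher number from compound 3 to compound 4 (0.04 log units; within the scatter)). The chloro and bromo compounds read the same way (a 1.2-fold higher number from compound 1 to compound 4 (0.07 log units; within the scatter); a 1.2-fold higher number from compound 2 to compound 4 (0.07 log units; within the scatter)). So this position accepts the loss of the halogen together with an added amine nitrogen, which the halogen exchanges alone could not show, and no supporting data explain this.

On these data alone, compound 4 joins both changes, so their separate contributions stay open. Also open, as far as these compounds go, is the outcome with a carboxylic acid on the benzothiazole or a longer chain in the link.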